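The compounds below may be only part of what the source reports. "The series", "measured", "known", "first", "only" and "open" are said of these compounds alone.

In an ADME assay on RAW264.7 cells (Mus musculus) for cytotoxicity, read by MTT assay, with a stated time of 48 h (a higher number here means that more compound is tolerated, a lower number that less compound is tolerated), compound 1 `Fc1ccc(NC(=S)N/N=C\c2ccnc3ccccc23)cc1` gives 45900 nM and compound 2 `S=C(N/N=C\c1ccnc2ccccc12)Nc1ccc(Cl)cc1` gives 63500 nM. For the measured compounds named here, these are the only two measurements so far, and they lie within the usual scatter of each other, so compound 2 cannot be separated from compound 1 on these numbers.

Compound 3 `C=CCNC(=S)N/N=C\c1ccnc2ccccc12` carries a larger structural change, with allyl in place of 4-chlorophenyl on an amide-type nitrogen. Going by the values given here, the one measured step that bears on this is a 1.4-fold higher number from compound 1 to compound 2 (0.14 log units; within the scatter). It put chloro in place of fluoro on an aromatic carbon and kept the aromatic ring, whereas compound 3 has no such ring in that place. That step therefore offers only weak guidance, and no measurement here shows what happens when the ring is replaced.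

With no evidence for either direction, no shift beyond the scatter is expected in this assay, and the expected change is a 1.3-fold lower number from compound 2 to compound 3 (0.10 log units; within the scatter). For compound 3 the estimated value is 50000 nM, with an expected range from 16000 nM to 150000 nM.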

Compound 3, half-maximal cytotoxic concentration: 105000 nM
Compound 3: middle estimate off by 2.1-fold (0.32 log units), on the low side; low and high end bracket the measured number.
By their numbers in this assay, from the lowest: compounds 1, 2 and 3 (each within the scatter of the next, the first and the last beyond it).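

For the compounds shown here, until now the only change at this amide-type nitrogen was chloro in place of fluoro, with the aromatic ring kept; here the whole ring is replaced. In this assay, going by these compounds alone, the swap of 4-chlorophenyl for allyl gives a 1.7-fold higher number from compound 2 to compound 3 (0.22 log units; within the scatter) and so cannot be told apart from the scatter, while the same swap starting from 4-fluorophenyl gives a 2.3-fold higher number from compound 1 to compound 3 (0.36 log units; beyond the scatter) and is the only step so far to clear the scatter, with more compound tolerated once the ring is gone. Nothing measured here accounts for this, so the shift stands as an observation without an explanation.

As far as these compounds go, what remains open is whether the loss of the ring or the double bond of allyl matters more: a saturated propyl chain would separate the two, and a cyclohexyl ring would show whether a ring that is not aromatic behaves like the aromatic ones. From the compounds shown here alone, it also remains open how this nitrogen would tolerate a chain ending in an amine or a carboxylic acid, since both groups that entered or left here carry neither.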